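The compounds below may be only part of what the source reports. "The series", "measured", "known", "first", "only" and "open" are said of these compounds alone.

Compound 1 `CNC(=O)c1ccccc1Oc1nc(Nc2ccc(C(F)(F)F)cc2)ncc1Br` and compound 2 `CNC(=O)c1ccccc1Oc1nc(Nc2cccc(C)c2)ncc1Br` share one core and differ only in the substituted aniline. In a functional assay on U-937 cells (Homo sapiens) for antiproliferative activity, read by MTT assay, with a stated time of 24 h (a higher number here means a weaker inhibitor, a lower number a stronger inhibitor), compound 1 gives > 50000 nM, which is a limit of the assay and not a number. Compound 1 therefore sits at the limit of > 50000 nM in this assay, at which 1 of the 2 values shown sits. In this assay, for the measured compounds named here, compound 2 gives 15900 nM, the only actual number among the values shown, so compound 2 stands alone as the one compound with a measured half-maximal inhibitory concentration.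

Compound 3 `CNC(=O)c1ccccc1Oc1nc(Nc2cccc(OC)c2)ncc1Br` differs from compound 2 by methoxy in place of methyl on an aromatic carbon. Going by the values given here, no step between two measured compounds matches this change, so the expectation rests on compound 2 alone. The expected step of a 1.2-fold lower number from compound 2 to compound 3 (0.09 log units; within the scatter) is small, no larger than the scatter of the assay, with no clear direction. Compound 3 is expected to give 13000 nM in this assay, within a range from 4000 nM to 45000 nM.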

Compound 3, half-maximal inhibitory concentration: 24300 nM
For compound 3 the middle estimate is 1.9-fold (0.27 log units) below the measured one, within the range that was stated.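

With compound 3, this assay gains its first step between two actual numbers: a 1.5-fold higher number from compound 2 to compound 3 (0.18 log units; within the scatter), for methoxy in place of methyl on an aromatic carbon, meta to a large group. This position therefore accepts the exchange, with its added oxygen and hydrogen-bond acceptor, without a change that can be told from the scatter, and both compounds remain in the same range of actual numbers. Nothing shown gives a measured property that bears on this step.

Compound 1 holds a limit and not a number, so steps that involve it cannot be read. Open, going by these compounds, is whether an amine, a carboxylic acid or a longer chain such as ethoxy at this place would move the value beyond the scatter.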